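The source may report more compounds than this note shows. Statements on the series, on what has been measured and on what is new or still open speak of the compounds shown alone.

Measured so far:
compound 1 `Nc1nc(N)nc(-c2ccccc2Br)n1` — in a functional assay on the whole organism with Rattus norvegicus as the target, at a dose of 20 mg/kg by the intraperitoneal route (on this read-out higher numbers stand for more inhibition at the one dose given (going by the name of the read-out) and lower numbers for less inhibition), compound 1 gives 26%
compound 2 `CS(=O)(=O)c1cccc(-c2nc(N)nc(N)n2)c1` — in this assay compound 2 gives -6%

Compound 2 stands lowest of the two numbers; its nearest neighbour is compound 1, whose number lies higher by a margin beyond the usual scatter. Compound 3 `Nc1nc(N)nc(-c2cccc(SC(F)(F)F)c2)n1` differs from compound 2 in one place: (trifluoromethyl)sulfanyl in place of methylsulfonyl on an aromatic carbon. Among the measured compounds shown here, no step between measured compounds is available to calibrate this change, so the expectation rests on the two numbers alone. The expected step of a number 16 percentage points higher from compound 2 to compound 3 (beyond the scatter) runs upward, though it may not reach beyond the scatter. In this assay compound 3 is estimated at 10%, within a range from -15% to 35%.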

Compound 3, a percentage reported as inhibition, in the whole organism at one dose (the size of the read-out at that dose, not a potency): 87%
For compound 3 the middle estimate is 77 percentage points below the measured one; measured number outside the range, above it.
By their numbers in this assay, from the lowest: compound 2; then compound 1; then compound 3.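

In this assay, (trifluoromethyl)sulfanyl in place of methylsulfonyl on an aromatic carbon gives a number 93 percentage points higher from compound 2 to compound 3 (beyond the scatter), a large step from a single change. It shows that the read-out is highly sensitive to the group on this aromatic carbon, which the two earlier compounds could not show because they differ in more than one place. Nothing at hand bears on what lies behind this step. As far as these compounds go, it remains open whether a plain trifluoromethyl, a methylsulfanyl or an amine on the same carbon would behave like (trifluoromethyl)sulfanyl or like methylsulfonyl.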